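The source may report more compounds than this note shows. Statements on the series, on what has been measured and on what is new or still open speak of the compounds shown alone.

In an ADME assay on MCF7-DOX cells (Homo sapiens) for cytotoxicity, read by MTT assay, with a stated time of 48 h (on this read-out higher numbers stand for weaker inhibition and lower numbers for stronger inhibition), compound 1 `COc1cc(OC)c(C(=O)/C=C/c2ccc(C(F)(F)F)cc2)c(O)c1CC=C(C)C` gives 73700 nM. Going by the values given here, of the two numbers so far it is the one at the upper end, yet compound 2 `COc1cc(O)c(C(=O)/C=C/c2cccc(N3CCN(C)CC3)c2)c(OC)c1`, which gives 62200 nM in this assay, lies within the scatter of it, and the two cannot be told apart. Compound 3 `COc1cc(OC)c(C(=O)/C=C/c2cccc(C(F)(F)F)c2)c(O)c1CC=C(C)C` has not been measured. It differs from compound 1 by 3-(trifluoromethyl)phenyl in place of 4-(trifluoromethyl)phenyl on a double-bonded chain carbon bound to a double-bonded chain carbon. Among the compounds with values here, no step between measured compounds is available to guide this change; the expected step of a 1.1-fold lower number from compound 1 to compound 3 (0.02 log units; within the scatter) is set at no more than the scatter, in no settled direction. Compound 3 is thus expected to give about 70000 nM, with a range from 30000 nM to 160000 nM.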

Compound 3, half-maximal inhibitory concentration: 66600 nM
The estimate for compound 3 lay 1.1-fold (0.02 log units) above the measured number, within the range that was stated.
By their numbers in this assay, from the lowest: compounds 2, 3 and 1 (each within the scatter of the next).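

Going by these compounds alone, the step of a 1.1-fold lower number from compound 1 to compound 3 (0.04 log units; within the scatter) in this assay gives the first direct reading at this place: 3-(trifluoromethyl)phenyl and 4-(trifluoromethyl)phenyl cannot be told apart on the core of compound 1. The earlier compounds shown here, with no step between them, could not show this. Nothing measured here bears on the reason for this result. The compounds shown leave open whether another group on this phenyl ring, such as a nitrile, an amine or a carboxylic acid, would give a number beyond the scatter of these.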